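Acyl group replacements on the shared core

The source may hold more compounds than are shown below. What is called first, only, known or untested is meant among the compounds shown, and "the series" means these compounds.

Compound 1 `O=C(NC[C@@H]1C[C@@H]2C=C[C@@H]1C2)NS(=O)(=O)N1CCC(CCNC(=O)C(F)(F)F)CC1` gives 22% in a functional assay on the whole organism (blood) with Rattus norvegicus as the target, with stated times of 24 h and 1 h, at a dose of 5 mg/kg by the intraperitoneal route; a higher number here means a stronger effect of the compound at the dose given, a lower number a weaker effect. Compound 2 `Cc1ncccc1C(=O)NCCC1CCN(S(=O)(=O)NC(=O)NC[C@@H]2C[C@@H]3C=C[C@@H]2C3)CC1` gives 16% in this assay, and compound 3 `COc1ccc(C(=O)NCCC2CCN(S(=O)(=O)NC(=O)NC[C@@H]3C[C@@H]4C=C[C@@H]3C4)CC2)cn1` gives 11%. Compound 3 stands lowest of the three numbers: its gap to compound 2 is within the scatter, its gap to compound 1 beyond it. The steps at the carbonyl carbon so far read a number 6 percentage points lower from compound 1 to compound 2 (within the scatter), a number 11 percentage points lower from compound 1 to compound 3 (beyond the scatter) and a number 5 percentage points lower from compound 2 to compound 3 (within the scatter). Compound 4 `O=C(NC[C@@H]1C[C@@H]2C=C[C@@H]1C2)NS(=O)(=O)N1CCC(CCNC(=O)c2nc3ccccc3s2)CC1` differs from compound 3 by 1,3-benzothiazol-2-yl in place of 6-methoxypyridin-3-yl on a carbonyl carbon. Among the measured compounds shown here, no measured step involves 1,3-benzothiazol-2-yl; the three exchanges on this carbonyl carbon were within the scatter or modest, so no step beyond the scatter is expected here, a number 1 percentage points lower from compound 3 to compound 4 (within the scatter). Compound 4 is therefore estimated at 10%, within a range from 2% to 20%.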

Compound 4, a percentage reported as activity, at one dose (the size of the read-out at that dose, not a potency): 24%
Compound 4: middle estimate off by 14 percentage points, on the low side, and the stated range ends below it.
By their numbers in this assay, from the lowest: compounds 3, 2, 1 and 4 (each within the scatter of the next, the first and the last beyond it).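

The acyl position is not tied to the low end of this assay when the group is aromatic: 1,3-benzothiazol-2-yl gives a number 13 percentage points higher from compound 3 to compound 4 (beyond the scatter) against 6-methoxypyridin-3-yl. Against 2-methylpyridin-3-yl the change reads a number 8 percentage points higher from compound 2 to compound 4 (within the scatter) and against trifluoromethyl a number 2 percentage points higher from compound 1 to compound 4 (within the scatter), so compound 4 and compound 1 cannot be separated here. No measurement at hand accounts for the step.

Open, from the compounds shown here alone, is whether the five-membered ring or the carbon-only ring carries the step. Going by these compounds, an acyl group bearing an amine or a carboxylic acid also remains open.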